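Amino for chloro on the fused benzene ring

The source may report more compounds than this note shows. Statements on the series, on what has been measured and on what is new or still open speak of the compounds shown alone.

Compound 2 `Nc1nn(C(=O)Nc2ccc(Cc3ccccc3)cc2)c2ccc(Cl)cc12` gives 35.7 nM in a functional assay on K562 cells (Homo sapiens) for antiproliferative activity, read by sulforhodamine B assay, with a stated time of 48 h; a higher number here means a weaker inhibitor of growth, a lower number a stronger inhibitor of growth. Within the data shown here, it stands lowest of the two numbers measured so far; the nearest neighbour is compound 1 `Nc1nn(C(=O)Nc2ccc(Cc3ccccc3)cc2)c2ccccc12`, which in this assay gives 1200 nM. Among the measured compounds shown here, the one measured step, a 34-fold lower number from compound 1 to compound 2 (1.53 log units; beyond the scatter), shows that the substituent at this place on the fused ring changes the number by a wide margin. Compound 3 `Nc1ccc2c(c1)c(N)nn2C(=O)Nc1ccc(Cc2ccccc2)cc1` differs from compound 2 by amino in place of chloro on an aromatic carbon. For the measured compounds named here, no measured step exchanges one substituent for another at that place, so the step from compound 2 to compound 3 has no direct precedent; only the large step from compound 1 to compound 2 bears on it, and it argues that a change here will be felt. The number for compound 3 is expected to move back toward that of compound 1, as an estimated step of a 14-fold higher number from compound 2 to compound 3 (1.15 log units; beyond the scatter). Compound 3 is therefore estimated at 500 nM in this assay, within a range of 100 nM to 2500 nM.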

Compound 3, concentration for 50% growth inhibition: 2240 nM
Compound 3: the middle estimate sits 4.5-fold (0.65 log units) below what was measured; the range from low to high includes it.
By their numbers in this assay, from the lowest: compound 2; then compounds 1 and 3 (each within the scatter of the next).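

In this assay, amino in place of chloro gives a 63-fold higher number from compound 2 to compound 3 (1.80 log units; beyond the scatter), so the low number of compound 2 does not carry over to this second substituent on the same aromatic carbon. Amino in place of hydrogen gives a 1.9-fold higher number from compound 1 to compound 3 (0.27 log units; within the scatter), which lies within the scatter: at this place amino cannot be told apart from hydrogen, and of the three compounds only the chloro compound, compound 2, stands apart. No evidence is at hand that accounts for this difference between chloro and amino.

From the compounds shown here alone, whether the low number is particular to chloro or is shared by fluoro, bromo, methyl or methoxy on the same carbon stays open. Also open, going by these compounds, is whether chloro would give a similar number on another carbon of this six-membered aromatic ring.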